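Estimating Lipophilicity for a Chloro Swap

The source may report more compounds than this note shows. Statements on the series, on what has been measured and on what is new or still open speak of the compounds shown alone.

- compound 1 `CCCC(Oc1ccc(-n2cc3c(n2)CCCC3)cc1)c1ccc(C(=O)NCCC(=O)O)cc1`: 2.7
- compound 2 `CCCC(Oc1ccc(-n2cc(C)cn2)cc1)c1ccc(C(=O)NCCC(=O)O)cc1`: 2.1

In a physicochemical assay for lipophilicity, using the shake flask method, at pH 7.4 (on this read-out higher numbers stand for higher lipophilicity and lower numbers for lower lipophilicity), compound 2 stands lowest of the two measured compounds at 2.1. The next one, compound 3 `CCCC(Oc1ccc(-n2cc(Cl)cn2)cc1)c1ccc(C(=O)NCCC(=O)O)cc1`, changes a single group: chloro in place of methyl on an aromatic carbon. For the measured compounds named here, only one measured step bears on this, a number 0.60 log units lower from compound 1 to compound 2 (beyond the scatter), and it involved a much larger group change. Going by the values given here, no measured step swaps these two groups, so the size and direction remain uncertain. The expected change is a slight rise, a number 0.20 log units higher from compound 2 to compound 3 (within the scatter), within the scatter. For compound 3 the estimate is 2.3, with an expected range of 2 to 2.6.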

Compound 3, distribution coefficient: 2.6
Estimate against measurement, compound 3: 0.30 log units below; measured number inside the range.
By their numbers in this assay, from the lowest: compound 2; then compounds 3 and 1 (each within the scatter of the next).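

In this assay, putting chloro in place of methyl on this aromatic carbon of the five-membered ring gives a number 0.50 log units higher from compound 2 to compound 3 (beyond the scatter), so a change of one heavy atom at this place is enough to move the number beyond the scatter. A far smaller group can also match a larger one here: a number 0.10 log units lower from compound 1 to compound 3 (within the scatter), a gap within the scatter.

From the compounds shown here alone, whether a fluoro, methoxy or nitrile group at this place would behave like chloro stays open. Nothing available gives a cause for either step.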